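Cytotoxicity notes: chloro in place of propanoyl

The source may report more compounds than this note shows. Statements on the series, on what has been measured and on what is new or still open speak of the compounds shown alone.

Compound 3 `CCC(=O)c1ccc(NCc2cncn2Cc2ccc(-c3ccccc3)cc2)cc1-c1ccccc1` is one of three compounds assessed so far in a toxicity assay on NIH3T3 cells (Mus musculus) for cytotoxicity, read by resazurin assay; a lower number here means that less compound is needed, a higher number that more compound is needed for the effect. In this assay compound 3 gives > 10000 nM, which is a limit of the assay rather than a number. Compound 1 `c1ccc(-c2ccc(Cn3cncc3CNc3ccc(-c4onc5ccccc45)c(-c4ccccc4)c3)cc2)cc1` gives > 10000 nM in this assay, also a limit. Compound 2 `c1ccc(-c2ccc(Cn3cncc3CNc3ccc(-c4cc5ccccc5o4)c(-c4ccccc4)c3)cc2)cc1` gives > 10000 nM in this assay, again a limit. Among the measured compounds shown here, all three values sit at the limit of > 10000 nM in this assay, at which 3 of the 3 values shown sit, so the steps among them, a step that the two limits leave unreadable from compound 1 to compound 2, a step that the two limits leave unreadable from compound 1 to compound 3 and a step that the two limits leave unreadable from compound 2 to compound 3, cannot be sized; they show only that exchanging the group on that aromatic carbon has not brought any of the three below the limit.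

Compound 4 `Clc1ccc(NCc2cncn2Cc2ccc(-c3ccccc3)cc2)cc1-c1ccccc1` differs from compound 3 by chloro in place of propanoyl on an aromatic carbon. Each measured step bears on this change in that each swaps the group on the same aromatic carbon, yet each is unreadable, so neither a direction nor a size can be taken from them. The expectation is accordingly that compound 4 also remains at the limit, with no step beyond the scatter, estimated as a step that the limit leaves unreadable from compound 3 to compound 4. For compound 4 the estimate in this assay is 20000 nM, within 5000 nM to 100000 nM.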

Compound 4, half-maximal effective concentration: > 1000 nM
Compound 4: only a limit was reported; the forecaster's own chance of this, stated with the estimate: 85%; the middle value does not contradict the limit.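

In this assay compound 4 gives > 1000 nM, which is a limit of the assay and not a number, so its steps from compound 1, compound 2 and compound 3 cannot be read. The compounds shown leave open whether any group on that aromatic carbon gives a readable value in this assay, and thus the direction and size of these exchanges.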